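Carbamate for carboxamide on the pyrazole-bearing core

This account rests on a few compounds, and the source may have more. Where it says the series, first, only, none or still open, it means among the compounds named here.

Compound 2 `Cc1cc(C(=O)NCc2ccncc2)nn1Cc1cc(Cl)ccc1OCc1ccccc1` sits at the second highest of three numbers in an assay on CHO-K1 cells for displacement of a labelled ligand from prostaglandin E2 receptor EP1 subtype (Homo sapiens) (on this read-out higher numbers stand for weaker inhibition and lower numbers for stronger inhibition), where it gives 79.4 nM. Its nearest neighbour is compound 1 `Cc1cc(C(=O)NCc2cccnc2)nn1Cc1cc(Cl)ccc1OCc1ccccc1`, which gives 50.1 nM, and its furthest is compound 3 `Cc1cc(C(N)=O)nn1Cc1cc(Cl)ccc1OCC(C)C`, which gives 126 nM; both of these lie within the scatter of compound 2, so no ordering among the three can be claimed.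

The new compound 4 `Cc1cc(NC(=O)OCc2ccccc2)nn1Cc1cc(Cl)ccc1OCc1ccccc1` differs from compound 2 as follows: (benzyloxycarbonyl)amino in place of ((pyridin-4-yl)methyl)carbamoyl on an aromatic carbon.

Among the measured compounds shown here, the only measured step, a 1.6-fold higher number from compound 1 to compound 2 (0.20 log units; within the scatter), swaps one ring position for another on the group that leaves here and so says nothing about a change that removes that whole group and puts a (benzyloxycarbonyl)amino in its place. Compound 3 shows that the shared core with a plain carbamoyl group and a different ether still reaches a number within the scatter of compound 2, which suggests some tolerance at this aromatic carbon, but compound 3 also differs in its ether and cannot settle the point. Without a bearing step, no shift beyond the scatter is expected in this assay, and compound 4 is estimated at 126 nM, between 30 nM and 600 nM, meaning a step of a 1.6-fold higher number from compound 2 to compound 4 (0.20 log units; within the scatter).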

Compound 4, half-maximal inhibitory concentration: 79.4 nM
Beside the measured number, compound 4's estimate is 1.6-fold (0.20 log units) above it; the range from low to high includes it.
By their numbers in this assay, from the lowest: compounds 1, 2, 4 and 3 (each within the scatter of the next, the first and the last beyond it).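

Replacing the group at this aromatic carbon of the shared core in this assay gives two readable steps: (no change at the digits printed from compound 2 to compound 4 (within the scatter)) and (a 1.6-fold higher number from compound 1 to compound 4 (0.20 log units; within the scatter)). Among the compounds shown here, the earlier compounds compared only two placements of the ring nitrogen within the pyridinylmethyl amide, whereas these steps show that the whole ((pyridin-4-yl)methyl)carbamoyl or ((pyridin-3-yl)methyl)carbamoyl group can give way to (benzyloxycarbonyl)amino, with its six-membered aromatic ring of carbon only, without a shift beyond the scatter, so on this core a ring nitrogen in this substituent is not needed to stay within the scatter of the pyridine compounds. No measurement shown gives a reason for this outcome.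

The compounds leave open whether this latitude extends to groups with no second aromatic ring at this position, such as a carboxylic acid, a free amine or a short alkyl amide on the same benzyl ether core. They also leave open whether (benzyloxycarbonyl)amino would behave alike with the 2-methylpropyl ether of compound 3 in place of the benzyl ether.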